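This account rests on a few compounds, and the source may have more. Where it says the series, first, only, none or still open, it means among the compounds named here.

In a functional assay on DU-145 cells (Homo sapiens) for inhibition, read by trypan blue exclusion, with a stated time of 96 h (on this read-out lower numbers stand for stronger inhibition of growth and higher numbers for weaker inhibition of growth), compound 3 (`O=C(/C(=C\c1ccccc1OCc1ccccc1)S(=O)(=O)Cc1ccc(F)cc1)c1ccc(Cl)cc1`) gives 10000 nM and stands level with compound 1 (`COc1ccccc1/C=C(/SCc1ccc(Cl)c(Cl)c1)C(=O)c1ccc(Cl)cc1`) at 10000 nM in this series, while compound 2 (`O=C(/C(=C\c1ccccc1OCc1ccccc1)S(=O)(=O)c1ccc(F)cc1)c1ccc(Cl)cc1`) gives the lower number of 1000 nM on this read-out. Compound 4 (`O=C(/C(=C\c1ccccc1OCc1ccccc1)SCc1ccc(Cl)c(Cl)c1)c1ccc(Cl)cc1`) has (3,4-dichlorobenzyl)sulfanyl in place of (4-fluorobenzyl)sulfonyl on a double-bonded chain carbon bound to a carbonyl carbon and a double-bonded chain carbon. For the measured compounds named here, the one measured step (a 10-fold higher number from compound 2 to compound 3 (1.00 log units; beyond the scatter)) changes only the group on the sulfonyl sulfur and does not test this swap. The entering group is already present in compound 1 (10000 nM), so no step beyond the scatter is expected in this assay from this change. The expected step is small (a 1.3-fold lower number from compound 3 to compound 4 (0.10 log units; within the scatter)). For compound 4 the estimated value is 8000 nM within an expected range from 2500 nM to 20000 nM on present data.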

Compound 4, concentration for 50% growth inhibition: 10000 nM
The estimate for compound 4 lay 1.3-fold (0.10 log units) below the measured number; measured number inside the range.
By their numbers in this assay, from the lowest: compound 2; then compounds 1, 3 and 4 (each within the scatter of the next).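

In this assay, the swap at this double-bonded chain carbon gives no change at the digits printed from compound 3 to compound 4 (within the scatter), so (3,4-dichlorobenzyl)sulfanyl and (4-fluorobenzyl)sulfonyl read alike here. Phenyl in place of hydrogen on the saturated chain carbon bound to an oxygen on an aromatic ring gives no change at the digits printed from compound 1 to compound 4 (within the scatter) here, while (3,4-dichlorobenzyl)sulfanyl in place of (4-fluorophenyl)sulfonyl gives a 10-fold higher number from compound 2 to compound 4 (1.00 log units; beyond the scatter) and leaves compound 2 with the lowest number of the series. No evidence on hand bears on these results. Open, on these data alone, is how a (4-fluorophenyl)sulfanyl group would read at this carbon, which would separate the sulfur group from the benzyl or phenyl group. Also open, as far as these compounds go, is whether an amine on the phenyl ring of the sulfonyl group would shift the number.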